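A few compounds are considered here, and "the series" means these few. Any claim that something is new, unique, unknown or untested is made for them only; others in the source may bear on it.

Compound 1 `Cc1nnsc1CO/N=C/c1c(C)nn(C)c1Oc1ccc(F)cc1` is the reference point of the series. In a functional assay on PANC-1 cells (Homo sapiens) for inhibition, read by MTT assay, with a stated time of 48 h (a higher number here means a weaker inhibitor, a lower number a stronger inhibitor), compound 1 gives > 50000 nM, which is a limit of the assay and not a number. The related compound 2 `Cc1nnsc1CO/N=C/c1c(C)nn(C)c1Oc1ccc(I)cc1` carries iodo in place of fluoro on an aromatic carbon. In this assay compound 2 gives > 50000 nM, again a limit of the assay rather than a measured number. The step that the two limits leave unreadable from compound 1 to compound 2 therefore cannot be read in size, since (the limit of > 50000 nM in this assay, at which 2 of the 2 values shown sit).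

Compound 3 `Cc1cccc(Oc2c(/C=N/OCc3snnc3C)c(C)nn2C)c1` differs from compound 1 by 3-methylphenyl in place of 4-fluorophenyl on an oxygen on an aromatic ring. Going by the values given here, no measured step bears on this change: the only step on record is the one just described, and it is unreadable. Among the compounds with values here, both values so far sit at the same limit, so there is no measured potency to move from and no direction to infer.

Compound 3 is therefore expected to return a limit as well, with a step that the limit leaves unreadable from compound 1 to compound 3 that is not separable from the scatter. The estimate for compound 3 in this assay is 60000 nM, within a range from 20000 nM to 200000 nM.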

Compound 3, half-maximal inhibitory concentration: > 50000 nM
Compound 3: only a limit was reported; the forecaster's own chance of this, stated with the estimate: 80%; the middle value is on the limit's open side.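

No new step can be read among compound 1, compound 2 and compound 3, since all three values are limits of the assay and not numbers: the limit of > 50000 nM in this assay, at which 3 of the 3 values shown sit.

The compounds shown leave open how far each lies beyond that limit in this assay, and whether any group on the oxygen of the shared core gives a measurable value.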